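A few compounds are considered here, and "the series" means these few. Any claim that something is new, unique, unknown or untested is made for them only; others in the source may bear on it.

Measured in a functional assay on Caco-2 cells (Homo sapiens) for inhibition, read by MTT assay, with a stated time of 48 h, tested at 10 uM; a higher number here means more inhibition of growth at the concentration tested, a lower number less inhibition of growth:
compound 1 `CCN(CC)Cc1c(O)c([C@H]2CCN(C)C[C@H]2O)c2oc(C)cc(=O)c2c1O`: 17%
compound 2 `Cc1cc(=O)c2c(O)c(CN3CCCC3CO)c(O)c([C@H]3CCN(C)C[C@H]3O)c2o1`: 19%

Compound 2, at 19%, cannot be told apart from compound 1, at 17%, since the two values lie within the scatter of each other. Compound 3 `CCOC(=O)N1CCN(Cc2c(O)c([C@H]3CCN(C)C[C@H]3O)c3oc(C)cc(=O)c3c2O)CC1` has not yet been measured. The change from compound 2 is 4-(ethoxycarbonyl)piperazin-1-yl in place of 2-(hydroxymethyl)pyrrolidin-1-yl on a saturated chain carbon bound to an aromatic carbon.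

Within the data shown here, only one measured step bears on this, a replacement at the same place: a number 2 percentage points higher from compound 1 to compound 2 (within the scatter). Among the measured compounds shown here, it is a single step, and no measured compound carries 4-(ethoxycarbonyl)piperazin-1-yl, so the evidence is thin and the range has to stay wide. With that one step as the guide, no shift beyond the scatter is expected in this assay. The expected change is a number 1 percentage points lower from compound 2 to compound 3 (within the scatter). For compound 3 the estimated value is 18%, with an expected range of 6% to 32%.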

Compound 3, percent growth inhibition at one concentration: 18%
Estimate against measurement, compound 3: no gap at the digits printed; the range from low to high includes it.
By their numbers in this assay, from the lowest: compounds 1, 3 and 2 (each within the scatter of the next).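

Notes on the series: in this assay, the place on a saturated chain carbon bound to an aromatic carbon now also carries a six-membered non-aromatic ring with 2 hetero atoms, as 4-(ethoxycarbonyl)piperazin-1-yl, with 11 heavy atoms and 0 hydrogen-bond donors against the 7 heavy atoms and 1 hydrogen-bond donor of 2-(hydroxymethyl)pyrrolidin-1-yl, and the read-out stays level, with a number 1 percentage points lower from compound 2 to compound 3 (within the scatter). The comparison with the open-chain diethylamino gives the same picture, with a number 1 percentage points higher from compound 1 to compound 3 (within the scatter), so across these three amines neither ring size, heavy-atom count nor the presence of a hydrogen-bond donor separates the compounds in this assay. No independent measurement is available to account for this flat result.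

Still open, as far as these compounds go, is whether any group at this place can move growth inhibition beyond the scatter in this assay. A carboxylic acid on the piperazine ring, a benzyl group in place of the ethoxycarbonyl, or a primary amine at the end of a longer chain would test this, and none of them appears among the compounds shown.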